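Methyl to Bromo on a Fused Aromatic Ring

The source may hold more compounds than are shown below. What is called first, only, known or untested is meant among the compounds shown, and "the series" means these compounds.

Compound 1 `COC(=O)[C@@]1(C)CCC=C2[C@@H]1CC[C@@H](C)[C@]2(C)Cc1c[nH]c2c(C)cccc12` and compound 2 `COC(=O)[C@@]1(C)CCC=C2[C@@H]1CC[C@@H](C)[C@]2(C)Cc1c[nH]c2c(Br)cccc12` share one core and differ only in bromo in place of methyl on an aromatic carbon. In a functional assay on A549 cells (Homo sapiens) for inhibition, read by sulforhodamine B assay, with a stated time of 48 h (on this read-out lower numbers stand for stronger inhibition of growth and higher numbers for weaker inhibition of growth), compound 1 gives 11000 nM, while compound 2 gives 22000 nM, so that this swap produced a 2.0-fold higher number from compound 1 to compound 2 (0.30 log units; within the scatter).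

Compound 3 `COC(=O)[C@@]1(C)CCC=C2[C@@H]1CC[C@@H](C)[C@]2(C)Cc1c(C)[nH]c2ccc(C)cc12` rests on a different core; how its core differs from that of compound 1 is not broken down here. In this assay compound 3 gives 26000 nM. Compound 4 `COC(=O)[C@@]1(C)CCC=C2[C@@H]1CC[C@@H](C)[C@]2(C)Cc1c(C)[nH]c2ccc(Br)cc12` is the still unmeasured partner of compound 3 and differs from it in bromo in place of methyl on an aromatic carbon. This is the same kind of change as that made from compound 1 to compound 2, but not the same one: in compound 2 the bromo sits ortho to a fused ring and meta to a fused ring, whereas in compound 4 it sits meta to a fused ring and para to a fused ring.

Among the compounds with values here, only one measured example of this swap exists here, so the expectation for compound 4 rests on it: the step is expected to be a 1.7-fold higher number from compound 3 to compound 4 (0.24 log units; within the scatter), in line with a 2.0-fold higher number from compound 1 to compound 2 (0.30 log units; within the scatter). Compound 4 is therefore estimated at 45000 nM in this assay. Within the data shown here, only a single precedent exists and the surroundings of the swap are not the same, so the expected range for compound 4 runs from 20000 nM to 90000 nM, meaning somewhat weaker inhibition of growth than compound 3 shows is expected, though a result close to that of compound 3 would not be surprising.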

Compound 4, concentration for 50% growth inhibition: 15000 nM
Estimate against measurement, compound 4: 3.0-fold (0.48 log units) above; the measured number lies below the stated range.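

In this assay, putting bromo in place of methyl on the core of compound 3 gives a 1.7-fold lower number from compound 3 to compound 4 (0.24 log units; within the scatter), and although this step and the earlier one each lie within the scatter when read alone, they point in opposite directions and the gap between them does not: the same change on two cores in this assay, a 2.0-fold higher number (0.30 log units; within the scatter) from compound 1 to compound 2 and a 1.7-fold lower number (0.24 log units; within the scatter) from compound 3 to compound 4, 3.5-fold (0.54 log units) apart, beyond the scatter of two such steps
This shows that, in this series, the swap cannot be treated as a fixed step that carries unchanged from one core to another, so the result on the core of compound 1 is a poor guide to the result on the core of compound 3. It does not show why the two steps part, since the cores differ and the bromo also sits in a different place, meta to a fused ring and para to a fused ring in compound 4, and two pairs cannot separate these influences or establish a general rule.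

The compounds shown leave open what bromo or methyl would do at one and the same place on both cores, which would separate the role of the core from the role of the position. They also leave open how a different group on that aromatic carbon, such as chloro, methoxy or an amine, would behave on either core.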